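The source may hold more compounds than are shown below. What is called first, only, known or untested is meant among the compounds shown, and "the series" means these compounds.

In an ADME assay on HepG2 2.2.15 cells (Homo sapiens) for cytotoxicity (on this read-out lower numbers stand for higher toxicity in this test and higher numbers for lower toxicity in this test), compound 1 `CC(C)C(=O)OCCc1c(-c2ccccc2Cl)c2cc(Cl)ccc2[nH]c1=O` gives 62000 nM, and compound 2 `O=C(OCCc1c(-c2ccccc2Cl)c2cc(Cl)ccc2[nH]c1=O)c1cccnc1` gives 170000 nM. Compound 3 `O=C(OCCc1c(-c2ccccc2Cl)c2cc(Cl)ccc2[nH]c1=O)c1cccs1` reports only a limit, > 1700000 nM.

These compounds differ only in the group on a carbonyl carbon, and that group clearly matters. Pyridin-3-yl in place of isopropyl gives a 2.7-fold higher number from compound 1 to compound 2 (0.44 log units; beyond the scatter), thiophen-2-yl in place of isopropyl gives an at least 27-fold higher number from compound 1 to compound 3 (1.43 log units; beyond the scatter), and thiophen-2-yl in place of pyridin-3-yl gives an at least 10-fold higher number from compound 2 to compound 3 (1.00 log units; beyond the scatter).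

Compound 4 `COc1cccc(/C=C/C(=O)OCCc2c(-c3ccccc3Cl)c3cc(Cl)ccc3[nH]c2=O)c1` swaps the thiophen-2-yl of compound 3 for 2-(3-methoxyphenyl)ethenyl: 2-(3-methoxyphenyl)ethenyl in place of thiophen-2-yl on a carbonyl carbon. Among the measured compounds shown here, no measured step tests this new group, so the three steps above serve only as a guide to size. The highest reading belongs to thiophen-2-yl, which now leaves, and the other two groups sit well lower, as an at least 10-fold higher number from compound 2 to compound 3 (1.00 log units; beyond the scatter) shows. A fall of similar size is therefore expected, though with wide uncertainty, and the estimate is an at least 8.5-fold lower number from compound 3 to compound 4 (0.92 log units; beyond the scatter). The expected value for compound 4 is 200000 nM, within an estimated range of 40000 nM to 1500000 nM.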

Compound 4, half-maximal cytotoxic concentration: > 1300000 nM
Compound 4: only a limit was reported (the forecaster's own chance of this, stated with the estimate: 20%); at least 6.5-fold (0.81 log units) between middle value and limit.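

In this assay compound 4 reports only a limit, > 1300000 nM. The high reading is therefore not confined to thiophen-2-yl: 2-(3-methoxyphenyl)ethenyl on the same carbonyl carbon, with a six-membered aromatic ring of carbon only, no sulfur and a double bond outside aromatic rings, also stands well clear of the two lower groups, with an at least 7.6-fold higher number from compound 2 to compound 4 (0.88 log units; beyond the scatter) and an at least 20-fold higher number from compound 1 to compound 4 (1.32 log units; beyond the scatter). The step between compound 3 and compound 4 cannot be read, as both results are limits, so neither group can be ranked above the other.

Going by these compounds, the true values of compound 3 and compound 4 remain unknown, so the full size of these gains is open too. Also open, on these data alone, is how a longer carbon chain, or a phenyl ring carrying an amine, would read at this position.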